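Phenyl to piperidin-1-yl on the sulfonyl sulfur

The compounds below may be only part of what the source reports. "The series", "measured", "known", "first", "only" and "open" are said of these compounds alone.

Values so far in a physicochemical assay for lipophilicity, measured as octanol-water partition, at pH 7.4; a lower number here means a more polar compound, a higher number a more lipophilic compound
- compound 1 `Cc1ccc2[nH]c(C(=O)N[C@H]3CN(S(=O)(=O)c4ccccc4)C[C@@H]3C(=O)NCCN(C)C)cc2c1` gives 2.1
- compound 2 `Cc1ccc2[nH]c(C(=O)N[C@H]3CN(S(=O)(=O)c4cccnc4)C[C@@H]3C(=O)NCCN(C)C)cc2c1` gives 1.4
- compound 3 `Cc1ccc2[nH]c(C(=O)N[C@H]3CCN(S(=O)(=O)c4ccccc4)C[C@@H]3C(=O)NCCN(C)C)cc2c1` gives 2.2

Compound 3 stands at 2.2 in this assay, within the scatter of compound 1 at 2.1. The gap from compound 3 to compound 2, whose lower value is 1.4 on the same scale, lies beyond the scatter.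

The next compound is compound 4 `Cc1ccc2[nH]c(C(=O)N[C@H]3CCN(S(=O)(=O)N4CCCCC4)C[C@@H]3C(=O)NCCN(C)C)cc2c1`, which carries piperidin-1-yl in place of phenyl on a sulfonyl sulfur. The ring that leaves is aromatic and the ring that enters is non-aromatic.

Going by the values given here, only one measured step changes the group on this sulfur: a number 0.70 log units lower from compound 1 to compound 2 (beyond the scatter), with pyridin-3-yl in place of phenyl. That step is modest, starts from compound 1 rather than compound 3, and brings in another aromatic ring, so it gives only a rough sense of size. Among the compounds with values here, no measured compound has a non-aromatic ring on the sulfur, and the data therefore give no direction for this change.

No shift beyond the scatter is expected in this assay, and the estimated move is no change at the digits printed from compound 3 to compound 4 (within the scatter) with a wide margin on either side. For compound 4 the expected value is 2.2, with an estimated range from 1.7 to 2.7.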

Compound 4, distribution coefficient: 2.3
Beside the measured number, compound 4's estimate is 0.10 log units below it, within the range that was stated.
By their numbers in this assay, from the lowest: compound 2; then compounds 1, 3 and 4 (each within the scatter of the next).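

In this assay, replacing phenyl with piperidin-1-yl on the sulfonyl sulfur gives a number 0.10 log units higher from compound 3 to compound 4 (within the scatter), so a non-aromatic ring at this position, the first among these compounds, reads the same within the scatter as the aromatic ring it replaces. The position therefore does not answer every ring exchange with a shift beyond the scatter, although pyridin-3-yl in place of phenyl gives a number 0.70 log units lower from compound 1 to compound 2 (beyond the scatter), and the two steps start from different parent compounds. A nitrogen in the entering ring is also not tied to a shift beyond the scatter here, as both pyridin-3-yl and piperidin-1-yl contain one, yet only the pyridin-3-yl step shows such a shift. No measurement available here explains why these two ring exchanges read differently.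

Still open, as far as these compounds go, is whether pyridin-3-yl on the sulfonyl sulfur of the compound 3 parent would repeat the step seen on the compound 1 parent. Also open, from the compounds shown here alone, is whether morpholin-4-yl, with its added ring oxygen, or an open-chain dimethylamino group on the same sulfur would read with compound 3 and compound 4 or apart from them.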